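The compounds below may be only part of what the source reports. "The series", "measured", "known", "first", "only" and "open" are said of these compounds alone.

Compound 1 `Brc1cn2ccnc2c(-c2ccc3ncn(C4CCCCC4)c3c2)n1`: 6.47%
Compound 2 `COc1ccc(-c2cn3ccnc3c(-c3ccc4ncn(C5CCCCC5)c4c3)n2)cc1`: 63.6%
Compound 3 `Brc1ccc(-c2cn3ccnc3c(-c3ccc4ncn(C5CCCCC5)c4c3)n2)cc1`: 18.4%

In a functional assay on SN12C cells (Homo sapiens) for inhibition, read by sulforhodamine B assay, with a stated time of 48 h, tested at 10 uM (on this read-out lower numbers stand for less inhibition and higher numbers for more inhibition at the one concentration tested (going by the name of the read-out)), compound 1 gives 6.47%, the lowest of the three numbers measured. Its nearest neighbour is compound 3, reached by a number 11.9 percentage points higher from compound 1 to compound 3 (beyond the scatter); the furthest is compound 2, reached by a number 57.1 percentage points higher from compound 1 to compound 2 (beyond the scatter). Between the two aryl compounds the change from methoxy to bromo is seen in a number 45.2 percentage points lower from compound 2 to compound 3 (beyond the scatter).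

Compound 4 `COc1ccccc1-c1cn2ccnc2c(-c2ccc3ncn(C4CCCCC4)c3c2)n1` has not yet been measured. It differs from compound 1 by 2-methoxyphenyl in place of bromo on an aromatic carbon. Among the measured compounds shown here, two measured steps bear on this change: both replacements of bromo by an aryl group raised the number, modestly in a number 11.9 percentage points higher from compound 1 to compound 3 (beyond the scatter) and strongly in a number 57.1 percentage points higher from compound 1 to compound 2 (beyond the scatter). The methoxy-bearing aryl group in particular lifted the number far beyond the scatter, though at a different position on that ring, so the size of the effect in compound 4 is uncertain. Compound 4 is therefore expected to show a rise in this assay of about a number 33.5 percentage points higher from compound 1 to compound 4 (beyond the scatter), beyond the scatter but with a wide range. The estimate for compound 4 is 40%, between 12% and 68%.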

Compound 4, a percentage reported as inhibition, at one concentration (the size of the read-out at that concentration, not a potency): 7.73%
The estimate for compound 4 lay 32.3 percentage points above the measured number; measured number below the stated range.
By their numbers in this assay, from the lowest: compounds 1 and 4 (each within the scatter of the next); then compound 3; then compound 2.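

In this assay, an aryl group at this position does not by itself raise the read-out: 2-methoxyphenyl in place of bromo gives a number 1.3 percentage points higher from compound 1 to compound 4 (within the scatter), so this replacement cannot be told apart from the bromo compound. The earlier compounds could not show that a methoxy-bearing phenyl ring may fail to give the high number, yet 2-methoxyphenyl in place of 4-methoxyphenyl gives a number 55.9 percentage points lower from compound 2 to compound 4 (beyond the scatter), and 2-methoxyphenyl in place of 4-bromophenyl gives a number 10.7 percentage points lower from compound 3 to compound 4 (beyond the scatter), so the high number belongs to the 4-methoxyphenyl compound alone among these aryl groups and not to methoxyphenyl as such. No measurement at hand explains why the two methoxyphenyl groups stand so far apart.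

The compounds shown leave open how an unsubstituted phenyl ring would read at this position, and whether a hydroxyphenyl, an aminophenyl or a phenyl ring carrying a carboxylic acid would stand nearer compound 2 or nearer compound 4. They also leave open whether the gap between compound 2 and compound 4 would hold if the cyclohexyl group of the shared core gave way to a shorter alkyl chain.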